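Methyl for methoxy on a benzothiazole-aryl pyrimidine

The source may report more compounds than this note shows. Statements on the series, on what has been measured and on what is new or still open speak of the compounds shown alone.

Compound 1 `COc1ccc2nc(Nc3ccnc(Nc4ccc(S(N)(=O)=O)cc4)n3)sc2c1`: 1480 nM
Compound 2 `NS(=O)(=O)c1ccc(Nc2ncc(F)c(Nc3nc4ccccc4s3)n2)cc1`: 3260 nM

Both compounds were tested in a functional assay on HCT-116 cells (Homo sapiens) for antiproliferative activity, read by MTT assay, with a stated time of 48 h; a lower number here means a stronger inhibitor, a higher number a weaker inhibitor. In this assay compound 1 gives 1480 nM, the lower of the two numbers, while compound 2 gives 3260 nM. Compound 3 `Cc1ccc2nc(Nc3ccnc(Nc4ccc(S(N)(=O)=O)cc4)n3)sc2c1` has not yet been measured. It differs from compound 1 in one place: methyl in place of methoxy on an aromatic carbon. For the measured compounds named here, no measured pair shows what such a change does here, so the expected step from compound 1 to compound 3 is small, in no clear direction, and likely within the usual scatter a 1.0-fold higher number from compound 1 to compound 3 (0.01 log units; within the scatter). Compound 3 is therefore estimated at 1500 nM, within a range of 600 nM to 4000 nM.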

Compound 3, half-maximal inhibitory concentration: 900 nM
Beside the measured number, compound 3's estimate is 1.7-fold (0.22 log units) above it, and the stated range covers the measured number.
By their numbers in this assay, from the lowest: compounds 3 and 1 (each within the scatter of the next); then compound 2.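

In this assay, putting methyl in place of methoxy on this aromatic carbon gives a 1.6-fold lower number from compound 1 to compound 3 (0.22 log units; within the scatter). For the compounds shown here, this is the first measured view of this change, and it shows that this position keeps its activity in this assay when the methoxy oxygen and its hydrogen-bond acceptor are gone. Nothing available explains this result.

The compounds shown leave open how an amine, a carboxylic acid or a longer chain on this same carbon would fare. They also leave open whether any group here could move the number beyond the usual scatter.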